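This account rests on a few compounds, and the source may have more. Where it says the series, first, only, none or still open, it means among the compounds named here.

Compound 1, `COc1cc([N+](=O)[O-])ccc1NC(=S)NC(C)=O`, was tested in an assay for inhibition of epoxide hydrolase 1 (Homo sapiens), read by fluorescence, using microsomes (on this read-out higher numbers stand for weaker inhibition and lower numbers for stronger inhibition), where compound 1 gives 1870 nM. A second measured compound, compound 2, `O=C(NC(=S)Nc1ccc(Br)c2ccccc12)c1ccccc1`, was run in the same assay, and compound 2 gives 1880 nM. The two numbers sit almost on top of each other, and the gap between them lies within the usual scatter of this assay, so neither compound can be set apart from the other on these data.

The next compound, compound 3, `COc1cc([N+](=O)[O-])ccc1NC(=S)NC(=O)c1ccccc1`, shares the core of compound 1 and differs from it in one place: phenyl in place of methyl on a carbonyl carbon. Among the measured compounds shown here, no pair of measured compounds that differ only in this way is available, so the size of the step has to be judged from what the two measured compounds show.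

Since compound 2, which also carries a phenyl on its carbonyl carbon, gives 1880 nM, a modest change is expected, with a small move toward stronger inhibition most likely, so that from compound 1 to compound 3 the estimated step is a 1.6-fold lower number from compound 1 to compound 3 (0.19 log units; within the scatter). For compound 3 the expected value in this assay is 1200 nM, with a range from 400 nM to 4000 nM.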

Compound 3, half-maximal inhibitory concentration: 1650 nM
Compound 3: middle estimate off by 1.4-fold (0.14 log units), on the low side, and the stated range covers the measured number.
By their numbers in this assay, from the lowest: compounds 3, 1 and 2 (each within the scatter of the next).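

In this assay, among the compounds shown here, this is the first direct reading of phenyl in place of methyl on a carbonyl carbon whose other neighbour is an amide-type nitrogen: a 1.1-fold lower number from compound 1 to compound 3 (0.05 log units; within the scatter). The two compounds therefore cannot be told apart, and this place on the core of compound 1 takes a six-membered aromatic ring of carbon only where a methyl stood, with no change that can be read in this assay. No measurement of any other kind bears on this result.

From the compounds shown here alone, what remains open is whether this place is equally undemanding for groups of other kinds, such as an amine or a carboxylic acid carried on the carbonyl carbon, a longer chain such as propyl, or a phenyl ring bearing a methoxy group. This single pair also cannot say whether phenyl and methyl would read alike on a different core, so the result holds for the core of compound 1 alone.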